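A few compounds are considered here, and "the series" means these few. Any claim that something is new, unique, unknown or untested is made for them only; others in the source may bear on it.

Compound 1 `Cc1cc(-n2ccc3ccccc32)cn2c(CSCCc3ccccc3)cnc12` and compound 3 `Cc1cc(-n2ccc3ccccc32)c2ncc(CSCCc3ccccc3)n2c1` are built from the same atoms joined differently; the difference between the two cores is not broken down here. In an ADME assay on HEL cells (Homo sapiens) for cytotoxicity, with a stated time of 3 days (on this read-out higher numbers stand for lower toxicity in this test and lower numbers for higher toxicity in this test), compound 1 gives > 20 ug/mL, which is a limit of the assay and not a number (the limit of > 20 ug/mL in this assay, at which 1 of the 3 values shown sits). Compound 2 `Cc1cc(-n2ccc3cccnc32)cn2c(CSCCc3ccccc3)cnc12` carries a group of 9 heavy atoms (7 carbon, 2 nitrogen; one five-membered aromatic ring with 1 hetero atom, one six-membered aromatic ring with 1 hetero atom) in place of a group of 9 heavy atoms (8 carbon, 1 nitrogen; one five-membered aromatic ring with 1 hetero atom, one six-membered aromatic ring of carbon only), on an aromatic carbon; in this assay compound 2 gives 20 ug/mL, and the step of a number no higher from compound 1 to compound 2 (the limit leaves the size open) is of a size the limit leaves open. In this assay compound 3 gives 100 ug/mL. Compound 4 `Cc1cc(-n2ccc3cccnc32)c2ncc(CSCCc3ccccc3)n2c1` carries the same kind of change, (a group of 9 heavy atoms (7 carbon, 2 nitrogen; one five-membered aromatic ring with 1 hetero atom, one six-membered aromatic ring with 1 hetero atom) in place of a group of 9 heavy atoms (8 carbon, 1 nitrogen; one five-membered aromatic ring with 1 hetero atom, one six-membered aromatic ring of carbon only), on an aromatic carbon), though here the place is ortho to a fused ring and meta to a fused ring, where in compound 2 it is para to a fused ring. Resting on compound 3 at 100 ug/mL and on the open size of the earlier step, the expected step is a 1.7-fold lower number from compound 3 to compound 4 (0.22 log units; within the scatter). Compound 4 is expected to give 60 ug/mL in this assay, between 20 ug/mL and 100 ug/mL.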

Compound 4, minimum cytotoxic concentration: 100 ug/mL
For compound 4 the middle estimate is 1.7-fold (0.22 log units) below the measured one; low and high end bracket the measured number.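

In this assay, the exchange of the 1H-indol-1-yl group gives no change at the digits printed from compound 3 to compound 4 (within the scatter). The value of compound 1 is a limit and not a number, so the earlier step cannot be read, and setting the two steps side by side settles nothing about their size: the same change on two cores in this assay, a number no higher (the limit leaves the size open) from compound 1 to compound 2 and no change at the digits printed (within the scatter) from compound 3 to compound 4; the limit leaves it open whether they differ The result therefore describes this exchange on the core of compound 3 alone; it does not show whether the change carries over to the other core with the same size.

The compounds shown leave open how an amine or a carboxylic acid at this place would read in this assay. They also leave open what a longer chain in place of the methyl group would do.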